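A few compounds are considered here, and "the series" means these few. Any claim that something is new, unique, unknown or untested is made for them only; others in the source may bear on it.

Compound 1, `O=c1[nH]cnc2c1c(-c1cccs1)cn2[C@@H]1O[C@H](CO)[C@@H](O)[C@H]1O`, compound 2, `Nc1nc2c(c(-c3cccs3)cn2[C@@H]2O[C@H](CO)[C@@H](O)[C@H]2O)c(=O)[nH]1`, and compound 3, `O=c1[nH]cnc2c1c(-c1ccccc1)cn2[C@@H]1O[C@H](CO)[C@@H](O)[C@H]1O`, were all tested in an ADME assay on BJ cells (Homo sapiens), read by MTT assay, with a stated time of 72 h; a higher number here means a weaker inhibitor, a lower number a stronger inhibitor. In this assay compound 1 gives > 100000 nM, which is a limit of the assay and not a number. In this assay compound 2 gives > 100000 nM, again a limit rather than a number. In this assay compound 3 gives > 100000 nM, also a limit.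

Compound 2 differs from compound 1 by amino in place of hydrogen on an aromatic carbon, and the resulting step is a step that the two limits leave unreadable from compound 1 to compound 2. Compound 3 differs from compound 1 in its core by phenyl in place of thiophen-2-yl on an aromatic carbon, and the step is a step that the two limits leave unreadable from compound 1 to compound 3. Neither step can be sized, since every measured value sits at the same limit.

Compound 4, `Nc1nc2c(c(-c3ccccc3)cn2[C@@H]2O[C@H](CO)[C@@H](O)[C@H]2O)c(=O)[nH]1`, has not yet been measured in this assay. It differs from compound 3 by amino in place of hydrogen on an aromatic carbon, the same change, at the same place, as that from compound 1 to compound 2. The step expected here, a step that the limit leaves unreadable from compound 3 to compound 4, rests on the unreadable earlier step that the two limits leave unreadable from compound 1 to compound 2 and on the fact that (the limit of > 100000 nM in this assay, at which 3 of the 3 values shown sit). Compound 4 is therefore expected to give 150000 nM in this assay, with an estimated range from 100000 nM to 300000 nM, and most likely to be reported only as a limit because of the limit of > 100000 nM in this assay, at which 3 of the 3 values shown sit.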

Compound 4, half-maximal inhibitory concentration: > 100000 nM
Compound 4 was reported as a limit; the forecaster's own chance of this, stated with the estimate: 90%; the middle value is on the limit's open side.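

Neither the step from compound 3 to compound 4 nor the step from compound 2 to compound 4 can be read in this assay, so neither the amino change nor the phenyl change can be given a size here: the limit of > 100000 nM in this assay, at which 4 of the 4 values shown sit.

The compounds shown leave open how far apart these four compounds truly lie, and whether any change to the shared core would give a readable value in this assay.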